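Adding a Methylpiperazine to a Weak Cytotoxic Amidine

The source may report more compounds than this note shows. Statements on the series, on what has been measured and on what is new or still open speak of the compounds shown alone.

Measured compounds:
- compound 1 `COc1ccc(Cn2nc(-c3ccccc3)c3cc(C(=N)Nc4ccc(N5CCN(C)CC5)cc4)nc(Nc4cc(OC)c(OC)c(OC)c4)c32)cc1`: 890 nM
- compound 2 `COc1ccc(Cn2nc(-c3ccccc3)c3cc(C(=N)Nc4ccccc4)nc(NC4CCCCC4)c32)cc1`: 3400 nM

In a functional assay on MDA-MB-231 cells (Homo sapiens) for cytotoxicity, read by MTT assay, with a stated time of 72 h (a higher number here means a weaker inhibitor, a lower number a stronger inhibitor), compound 1 gives 890 nM and compound 2 gives 3400 nM. Compound 2 therefore stands at the highest number of the two, a gap from compound 1 that lies beyond the scatter. Compound 3 `COc1ccc(Cn2nc(-c3ccccc3)c3cc(C(=N)Nc4ccc(N5CCN(C)CC5)cc4)nc(NC4CCCCC4)c32)cc1` differs from compound 2 in one place: 4-methylpiperazin-1-yl in place of hydrogen on an aromatic carbon. Within the data shown here, compound 1 carries the same group and sits lower, but also differs elsewhere, so no single clean step exists. A modest decrease in this assay is expected, a 2.1-fold lower number from compound 2 to compound 3 (0.33 log units; beyond the scatter). Compound 3 is expected at 1600 nM, within 500 nM to 4500 nM.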

Compound 3, half-maximal inhibitory concentration: 129000 nM
Compound 3: middle estimate off by 81-fold (1.91 log units), on the low side; the whole stated range lies below it.
By their numbers in this assay, from the lowest: compound 1; then compound 2; then compound 3.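

In this assay, 4-methylpiperazin-1-yl on this aromatic carbon proves costly when cyclohexyl is the group on the nitrogen: the change brings a 38-fold higher number from compound 2 to compound 3 (1.58 log units; beyond the scatter), a large loss of activity. With 4-methylpiperazin-1-yl held in place, the group on that nitrogen also matters greatly, since cyclohexyl in place of 3,4,5-trimethoxyphenyl gives a 140-fold higher number from compound 1 to compound 3 (2.16 log units; beyond the scatter) in this cell assay. No evidence here bears on the cause of either step. As far as these compounds go, whether 4-methylpiperazin-1-yl costs as much alongside 3,4,5-trimethoxyphenyl remains open. So does whether a morpholine ring on the same carbon would behave the same way.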